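The source may report more compounds than this note shows. Statements on the series, on what has been measured and on what is new or still open speak of the compounds shown alone.

Measured compounds:
compound 1, `O=[N+]([O-])c1cccc(COCNc2n[n+]([O-])c3ccccc3[n+]2[O-])c1`, 650 nM
compound 2, `COCNc1n[n+]([O-])c2ccccc2[n+]1[O-]`, 3790 nM
compound 3, `COc1ccc2c(c1)[n+]([O-])nc(NCOCc1ccccc1)[n+]2[O-]`, 240 nM

In a functional assay on K562 cells (Homo sapiens) for cytotoxicity, read by MTT assay, with a stated time of 72 h (on this read-out lower numbers stand for stronger inhibition and higher numbers for weaker inhibition), compound 2 gives 3790 nM, the highest number of the three. The nearest to it is compound 1, which in this assay gives 650 nM, a gap that lies beyond the usual scatter. Furthest from it is compound 3, which in this assay gives 240 nM, again beyond the scatter.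

Compound 4, `CC(C)CCOCNc1n[n+]([O-])c2ccccc2[n+]1[O-]`, has not yet been measured. It differs from compound 2 in a single place: isobutyl in place of hydrogen on a saturated chain carbon bound to an oxygen on a saturated carbon. Within the data shown here, no step between measured compounds that differ in only one place is available, so any expectation rests on the three values alone. Compound 1 and compound 3 both carry more than a methyl beyond the oxygen on a saturated carbon, and both give lower numbers than compound 2, though compound 3 also differs in its core, so this is a loose guide rather than a pattern.

On that basis compound 4 is expected to give a lower number than compound 2, with an expected step of a 3.2-fold lower number from compound 2 to compound 4 (0.50 log units; beyond the scatter). Compound 4 is estimated in this assay at 1200 nM, within a range from 400 nM to 3500 nM.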

Compound 4, half-maximal inhibitory concentration: 5850 nM
Estimate against measurement, compound 4: 4.9-fold (0.69 log units) below, and the stated range ends below it.
By their numbers in this assay, from the lowest: compound 3; then compound 1; then compounds 2 and 4 (each within the scatter of the next).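

In this assay, isobutyl in place of hydrogen on a saturated chain carbon bound to an oxygen on a saturated carbon gives a 1.5-fold higher number from compound 2 to compound 4 (0.19 log units; within the scatter), so the two compounds cannot be told apart at this place. Among these compounds, this is the first single-place step that can be read, and it shows that these added carbon atoms, with no ring among them, do not by themselves take the number beyond the scatter, whereas compound 1, which has a ring-bearing group beyond the same oxygen, gives 650 nM. Nothing available here accounts for this result.

The compounds shown leave open whether the lower number of compound 1 goes with its ring or with its nitro group, since no compound here carries one without the other in that place on the same core. They also leave open how the number would respond to an amine or a carboxylic acid at the end of the chain in place of isobutyl.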